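Removing a Trifluoromethyl Group: What to Expect

The source may hold more compounds than are shown below. What is called first, only, known or untested is meant among the compounds shown, and "the series" means these compounds.

Compound 1, `Nc1scc(-c2ccccc2)c1C(=O)c1ccccc1`: 49%
Compound 2, `Nc1scc(-c2cccc(C(F)(F)F)c2)c1C(=O)c1ccc(Cl)cc1`: 64%

Of the compounds shown here, two with a shared core have been measured in a functional assay on CHO cells for agonist activity at adenosine receptor A1 (Homo sapiens), read by fluorescence and ERK phosphorylation, with stated times of 30 min and 1.5 h, tested at 3 uM; a lower number here means a weaker effect, a higher number a stronger effect of the compound at the concentration tested. In this assay compound 1 gives 49%, while compound 2 gives 64%. Compound 2 therefore stands highest of the two numbers, and its nearest neighbour, compound 1, lies a distance below it that exceeds the usual scatter. Compound 2 differs from compound 1 in two places at once, so that gap cannot be tied to either change alone.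

Compound 3, `Nc1scc(-c2ccccc2)c1C(=O)c1ccc(Cl)cc1`, has not yet been measured. It keeps the rest of compound 2 unchanged and differs in one place: hydrogen in place of trifluoromethyl on an aromatic carbon. Compound 2 gives 64% and compound 1 gives 49%; compound 3 sits between them in structure, so its number is expected to lie between them. The expected step is a number 8 percentage points lower from compound 2 to compound 3 (within the scatter), a modest fall roughly the size of the scatter. Compound 3 is estimated at 56%, with a range from 42% to 70%.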

Compound 3, a percentage reported as activity, at one concentration (the size of the read-out at that concentration, not a potency): 51%
Beside the measured number, compound 3's estimate is 5 percentage points above it, within the range that was stated.
By their numbers in this assay, from the lowest: compounds 1 and 3 (each within the scatter of the next); then compound 2.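

In this assay, the trifluoromethyl group now has an effect that can be read on its own: replacing it with hydrogen gives a number 13 percentage points lower from compound 2 to compound 3 (beyond the scatter), a modest step that the two earlier compounds, differing in two places at once, could not isolate. The chloro change can also be read alone, and it gives a number 2 percentage points higher from compound 1 to compound 3 (within the scatter), so when hydrogen holds this position the chloro group makes no difference that stands out from the scatter. No measurement shown bears on why the trifluoromethyl group matters here.

From the compounds shown here alone, whether a methyl group, a methoxy group or a nitrile at this position would keep the higher number remains open. Also open, going by these compounds, is whether the chloro group would count for more with trifluoromethyl present, and these single-concentration numbers say nothing about potency.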